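Cytotoxicity notes: methyl to cyano on the side-chain phenyl

A few compounds are considered here, and "the series" means these few. Any claim that something is new, unique, unknown or untested is made for them only; others in the source may bear on it.

Measured compounds
Compound 1 `Cc1cc(C)nc(Sc2ccnc(Nc3ccc(C#N)cc3)n2)n1`: 224000 nM
Compound 2 `Cc1ccccc1COc1ccnc(Nc2ccc(C#N)cc2)n1`: 12000 nM
Compound 3 `COc1cc(COc2ccnc(Nc3ccc(C#N)cc3)n2)cc(OC)c1`: 44200 nM

All three were read in an ADME assay on MT4 cells (Homo sapiens) for cytotoxicity, read by MTT assay, with a stated time of 5 days; a lower number here means that less compound is tolerated, a higher number that more compound is tolerated. Compound 2 gives the lowest of the three numbers in this assay, compound 3 a higher one and compound 1 the highest; both gaps from compound 2 lie beyond the scatter. Compound 4 `N#Cc1ccc(Nc2nccc(OCc3ccccc3C#N)n2)cc1` is the pending member. Against compound 2 it carries cyano in place of methyl on an aromatic carbon. Going by the values given here, no step between two measured compounds isolates this change, so there is no direct guide to its size. The expectation is that the step stays within the scatter, if anything toward a higher number: a 1.5-fold higher number from compound 2 to compound 4 (0.18 log units; within the scatter). Compound 4 is therefore expected to give about 18000 nM in this assay, with a range from 6000 nM to 60000 nM.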

Compound 4, half-maximal cytotoxic concentration: 113000 nM
Beside the measured number, compound 4's estimate is 6.3-fold (0.80 log units) below it, outside the stated range (above it).
By their numbers in this assay, from the lowest: compound 2; then compound 3; then compounds 4 and 1 (each within the scatter of the next).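

In this assay, cyano in place of methyl on an aromatic carbon, ortho to a large group, gives a 9.4-fold higher number from compound 2 to compound 4 (0.97 log units; beyond the scatter) with nothing else changed, so this position of the side-chain phenyl is not neutral to the change. Going by these compounds alone, the earlier compounds offered no single-place step, and this is the first size available for any change. No measurement at hand accounts for the size of this step.

Open, from the compounds shown here alone, is whether a carboxylic acid or an amine in this place would move the number in the same direction. Also open, going by these compounds, is whether cyano elsewhere on the same ring would give a step of similar size.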